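A few compounds are considered here, and "the series" means these few. Any claim that something is new, unique, unknown or untested is made for them only; others in the source may bear on it.

Compounds measured so far in an ADME assay on HEK-293T cells (Homo sapiens) for cytotoxicity, read by CCK-8 assay, with a stated time of 48 h; on this read-out lower numbers stand for stronger inhibition and higher numbers for weaker inhibition:
- compound 1 `O=C(NCCNS(=O)(=O)c1ccc(-c2ccccc2Oc2ccc([N+](=O)[O-])c([N+](=O)[O-])c2)s1)Nc1cc(Cl)cc(Cl)c1` — > 20000 nM, a limit of the assay, not a number
- compound 2 `O=C(NCCNS(=O)(=O)c1ccc(-c2ccccc2Oc2ccc([N+](=O)[O-])c([N+](=O)[O-])c2)s1)Nc1ccc(Cl)cc1` — > 20000 nM, likewise a limit
- compound 3 `Cc1cc(C)cc(NC(=O)NCCNS(=O)(=O)c2ccc(-c3ccccc3OCc3cccc(O)c3)s2)c1` — > 20000 nM, likewise a limit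

Compound 3 therefore stands at the limit of this assay, as do the other two compounds shown; no measured number separates any of them. Among the measured compounds shown here, the only step between measured compounds that differ in one place is a step that the two limits leave unreadable from compound 1 to compound 2, and its size cannot be read because the limit of > 20000 nM in this assay, at which 3 of the 3 values shown sit, holds both ends of it.

Compound 4 `Cc1cc(C)cc(NC(=O)NCCNS(=O)(=O)c2ccc(-c3ccccc3Oc3ccc([N+](=O)[O-])c([N+](=O)[O-])c3)s2)c1` is not yet measured. It differs from compound 3 by 3,4-dinitrophenyl in place of 3-hydroxybenzyl on an oxygen on an aromatic ring. For the measured compounds named here, no measured step bears directly on this change. What can be said is that compounds 1 and 2, which both carry the 3,4-dinitrophenyl group on the oxygen on the aromatic ring, sit at the limit together with compound 3, so that entering this group has so far not been seen alongside any readable cytotoxicity.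

Compound 4 is therefore expected to sit at the limit as well, with a step that the limit leaves unreadable from compound 3 to compound 4 that cannot be distinguished from no change. The estimate for compound 4 in this assay is 30000 nM, within 15000 nM to 80000 nM.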

Compound 4, half-maximal inhibitory concentration: > 50000 nM
Compound 4: only a limit was reported (the forecaster's own chance of this, stated with the estimate: 85%); at least 1.6-fold (0.22 log units) between middle value and limit.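

Among the compounds shown here, compound 4 gives > 50000 nM, a limit and not a number, so no step from compound 1, compound 2 or compound 3 to compound 4 can be read. The compounds shown leave open whether either change, on the oxygen or on the amide-type nitrogen, shifts the read-out in this assay, as every value is a limit.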